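This account rests on a few compounds, and the source may have more. Where it says the series, first, only, none or still open, it means among the compounds named here.

Compound 1 `O=C(CCCCC1CCSS1)Nc1cccc(C(F)(F)F)c1`: "not active" (no number reported)
Compound 2 `O=C(CCCCC1CCSS1)Nc1ccc([N+](=O)[O-])c(C(F)(F)F)c1`: 18.8%
Compound 3 `O=C(CCCCC(S)CCS)Nc1cccc(C(F)(F)F)c1`: 12%

All three compounds were tested in a functional assay on NCI-H460 cells (Homo sapiens) for inhibition, read by MTT assay, with a stated time of 24 h, tested at 0.1 ug/mL; on this read-out higher numbers stand for more inhibition of growth at the one concentration tested and lower numbers for less inhibition of growth. In this assay compound 3 gives 12%, which lies within the scatter of compound 2 at 18.8%. Compound 1 has no number, only the report "not active" (no number reported), so compound 3 can be placed against one numerical neighbour alone.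

The next compound, compound 4 `O=C(CCCCC(S)CCS)Nc1ccc([N+](=O)[O-])c(C(F)(F)F)c1`, keeps the open chain of compound 3 and changes the aromatic ring: nitro in place of hydrogen on an aromatic carbon. This is nitro in place of hydrogen on an aromatic carbon, ortho to a trifluoromethyl group. Among the measured compounds shown here, no measured pair of compounds gives the size of this change directly. The nearest guide is compound 2, which carries the same nitro and gives 18.8%. A small upward move in this assay is therefore expected, not one beyond the scatter. The expected step of a number 6 percentage points higher from compound 3 to compound 4 (within the scatter) reflects this. For compound 4 the estimated value is 18%, with an expected range from 6% to 35%.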

Compound 4, percent growth inhibition at one concentration: 3.2%
Estimate against measurement, compound 4: 14.8 percentage points above; the whole stated range lies above it.
By their numbers in this assay, from the lowest: compounds 4, 3 and 2 (each within the scatter of the next, the first and the last beyond it).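

On the open-chain compounds, placing a nitro ortho to a trifluoromethyl group does not shift the read-out in this assay beyond the usual scatter, with a number 8.8 percentage points lower from compound 3 to compound 4 (within the scatter). With the nitro present, the ring-for-chain exchange on the saturated chain carbon does give a modest step beyond the scatter, with a number 15.6 percentage points lower from compound 2 to compound 4 (beyond the scatter), so the form of the sulfur-bearing end matters more here than the nitro did on the open chain. The data offer no measured basis for explaining either step.

The compounds shown leave open whether a nitrile or an amine in place of the nitro at this position would separate from compound 3 beyond the scatter. They also leave open whether a longer chain would preserve the difference seen between compound 2 and compound 4.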